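A few compounds are considered here, and "the series" means these few. Any claim that something is new, unique, unknown or untested is made for them only; others in the source may bear on it.

Measured so far:
compound 1 `Oc1cccc(-c2cc(-c3ccc(Cl)cc3)nc(-c3cccs3)c2)c1`, an assay on isolated protein for inhibition of DNA topoisomerase 1 (Homo sapiens), with a stated time of 30 min, tested at 20 uM; a lower number here means a weaker effect, a higher number a stronger effect of the compound at the concentration tested: "not determined" (no result reported)
compound 2 `Oc1ccc(-c2cc(-c3ccc(Cl)cc3)nc(-c3cccs3)c2)cc1`, this assay: 0%

Compound 1 stands on no single number in this assay, since no result was reported for it. Compound 2, which carries its hydroxyl on a different carbon of the same phenyl ring, gives 0% in this assay. Compound 3 `Oc1cccc(-c2cc(-c3ccc(Cl)cc3)nc(-c3ccccn3)c2)c1` differs from compound 1 in one place: pyridin-2-yl in place of thiophen-2-yl on an aromatic carbon. For the measured compounds named here, with no step between measured compounds to lean on, and compound 2 showing no inhibition, a shift of at most the usual scatter is expected, in no firm direction. Compound 3 is therefore expected to give about 5% in this assay, within 0% to 25%.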

Compound 3, a percentage reported as inhibition, at one concentration (the size of the read-out at that concentration, not a potency): 0%
Estimate against measurement, compound 3: 5 percentage points above; the measured number falls inside the stated range.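

In this assay compound 1 stands at "not determined" (no result reported) and compound 3 at 0%, so no step can be read between them. The compounds shown leave open whether pyridin-2-yl in place of thiophen-2-yl changes inhibition at all. No supporting evidence bears on these results.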